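The source may report more compounds than this note shows. Statements on the series, on what has been measured and on what is new or still open speak of the compounds shown alone.

Of the compounds shown here, two sharing one core have been measured here. Compound 1 `O=C(CCl)NC(=O)Nc1ccc(OC2CCCC2)cc1` and compound 2 `O=C(CCl)NC(=O)Nc1ccc(OCc2ccccc2)cc1` differ only in the group on the ring oxygen. In a functional assay on MCF7 cells (Homo sapiens) for inhibition, read by sulforhodamine B assay, with a stated time of 48 h (on this read-out lower numbers stand for stronger inhibition of growth and higher numbers for weaker inhibition of growth), compound 1 gives 3900 nM, and compound 2 gives 4600 nM. The change a 1.2-fold higher number from compound 1 to compound 2 (0.07 log units; within the scatter) shows that this swap makes no visible difference. Compound 1 thus has the lower of the two numbers, though only by a margin that says nothing.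

Compound 3 `Cc1ccc(NC(=O)NC(=O)CCl)cc1` is not yet measured. It differs from compound 1 by methyl in place of cyclopentyloxy on an aromatic carbon. For the measured compounds named here, no measured step involves this kind of change; the only step known alters the group beyond the oxygen rather than removing the oxygen itself, so it offers little guidance. The expectation is therefore a step of a 1.5-fold higher number from compound 1 to compound 3 (0.19 log units; within the scatter) with wide uncertainty. For compound 3 the estimate in this assay is 6000 nM, expected to lie between 2000 nM and 18000 nM.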

Compound 3, concentration for 50% growth inhibition: 7500 nM
Estimate against measurement, compound 3: 1.3-fold (0.10 log units) below, and the stated range covers the measured number.
By their numbers in this assay, from the lowest: compounds 1, 2 and 3 (each within the scatter of the next).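

In this assay, putting a single methyl in place of the whole cyclopentyloxy group gives a 1.9-fold higher number from compound 1 to compound 3 (0.28 log units; within the scatter), so even this much larger change at the aromatic carbon cannot be told apart from repeat-to-repeat noise. The earlier step altered only what lies beyond the oxygen, whereas this one removes the oxygen and the five-membered ring together, and the read-out still does not separate the two compounds. Nothing available here gives a reason for this result.

It remains open whether any group in this place can move the number beyond the scatter, as the three compounds shown each lie within the scatter of the next. An amine or a carboxylic acid at this carbon, or a longer chain on the oxygen, would put that question to the test.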